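Trifluoromethyl in place of methyl on compound 2

This account rests on a few compounds, and the source may have more. Where it says the series, first, only, none or still open, it means among the compounds named here.

Measured so far in a functional assay on NCI-H460 cells (Homo sapiens) for antiproliferative activity, read by MTT assay, with a stated time of 48 h (a higher number here means a weaker inhibitor, a lower number a stronger inhibitor), for three compounds with a shared core:
- compound 1 `CCCCC1(O)C(=O)Nc2ccc(Nc3ccc(C)cc3)cc21` gives 31800 nM
- compound 2 `Cc1ccc(Nc2ccc3c(c2)C(O)(CCC(C)C)C(=O)N3)cc1` gives 22700 nM
- compound 3 `Cc1ccc(Nc2ccc3c(c2)C(O)(Cc2ccccc2)C(=O)N3)cc1` gives 31600 nM

Compound 2 cannot be separated from the other two compounds, since all three numbers lie within the usual scatter of each other. Compound 4 `CC(C)CCC1(O)C(=O)Nc2ccc(Nc3ccc(C(F)(F)F)cc3)cc21` has not yet been measured. It differs from compound 2 in one place, on an aromatic carbon of a six-membered aromatic ring of carbon only, para to a large group. The change is trifluoromethyl in place of methyl on an aromatic carbon.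

All three measured steps alter the chain, not this aromatic position (a 1.4-fold lower number from compound 1 to compound 2 (0.15 log units; within the scatter); a 1.0-fold lower number from compound 1 to compound 3 (0.00 log units; within the scatter); a 1.4-fold higher number from compound 2 to compound 3 (0.14 log units; within the scatter)). Each is small and within the scatter, but none tests the new group. Every measured compound carries methyl at this spot. In this assay no step beyond the scatter is therefore expected, and neither direction can be favoured. The expected size is a 1.0-fold lower number from compound 2 to compound 4 (0.01 log units; within the scatter) and it remains only an estimate. The starting point for it is compound 2 (22700 nM). The estimate for compound 4 is 22000 nM (expected range 9000 nM to 50000 nM).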

Compound 4, half-maximal inhibitory concentration: 17200 nM
Estimate against measurement, compound 4: 1.3-fold (0.11 log units) above; measured number inside the range.
By their numbers in this assay, from the lowest: compounds 4, 2, 3 and 1 (each within the scatter of the next).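

In this assay, for the compounds shown here, this is the first step that changes the aromatic carbon para to a large group, and it gives a 1.3-fold lower number from compound 2 to compound 4 (0.12 log units; within the scatter). The position therefore takes trifluoromethyl, with 4 heavy atoms in place of the 1 heavy atom of methyl, without a change that can be told apart from the normal spread of repeated measurements. So compound 4 offers no sign that this swap either helps or harms antiproliferative activity in these cells, and no independent measurement is available to explain the result in either direction.

Going by these compounds, this single swap says little about the position as a whole, so it remains open whether an amine, a carboxylic acid or a longer chain at the same aromatic carbon would produce a step beyond the scatter. Going by these compounds alone, it is also open whether trifluoromethyl would behave the same way alongside the chains of compound 1 and compound 3, since here it is seen only with the chain of compound 2.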